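This account rests on a few compounds, and the source may have more. Where it says the series, first, only, none or still open, it means among the compounds named here.

In a functional assay on cells (Cancer cell lines, Homo sapiens) for inhibition (a higher number here means a weaker inhibitor of growth, a lower number a stronger inhibitor of growth), compound 1 (`Cc1cn2c(/C=N/NC(=N)N)c(-c3ccsc3)nc2s1`) gives 13800 nM and compound 3 (`N=C(N)N/N=C/c1c(-c2ccsc2)nc2sccn12`) gives 15100 nM as its value. Hydrogen in place of methyl on an aromatic carbon thus makes only a small step (a 1.1-fold higher number from compound 1 to compound 3 (0.04 log units; within the scatter)). Compound 2 (`N=C(N)N/N=C/c1c(-c2cc(Cl)sc2Cl)nc2n1CCS2`), on a different core, gives 11200 nM and stands within the scatter of both others, so the three values show no order.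

Compound 4 (`N=C(N)N/N=C/c1c(-c2cccs2)nc2n1CCS2`) carries thiophen-2-yl in place of 2,5-dichlorothiophen-3-yl on an aromatic carbon. Among the measured compounds shown here, no measured step covers this change. For the measured compounds named here, the one step available, from compound 1 to compound 3, lies at another place in the molecule and bears on it only indirectly, as a sign of how flat these values are so far. Compound 3, which has no chlorine on its thiophene, still gives a value close to that of compound 2, although the cores differ. For compound 4, no change beyond the scatter is expected in this assay (a 1.2-fold higher number from compound 2 to compound 4 (0.06 log units; within the scatter)). The estimated value for compound 4 is 13000 nM (expected range 6000 nM to 30000 nM).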

Compound 4, concentration for 50% growth inhibition: 28800 nM
Estimate against measurement, compound 4: 2.2-fold (0.35 log units) below; the measured number falls inside the stated range.
By their numbers in this assay, from the lowest: compounds 2, 1, 3 and 4 (each within the scatter of the next, the first and the last beyond it).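

In this assay, among the compounds shown here, this position on an aromatic carbon next to the ring nitrogen gives the first step that lies beyond the scatter, a 2.6-fold higher number from compound 2 to compound 4 (0.41 log units; beyond the scatter), whereas the hydrogen-for-methyl change elsewhere in the molecule gave only a 1.1-fold higher number from compound 1 to compound 3 (0.04 log units; within the scatter). The values are therefore not flat across all positions, although this single step is modest and combines two differences: the loss of both chlorine atoms and a different point of attachment on the thiophene. No measurement of any property bears on this step, and the data offer no explanation for it.

The compounds shown leave open whether the chlorine atoms or the point of attachment accounts for the step, which thiophen-3-yl on the core of compound 2 could help to separate. They also leave open how this position would respond to a group outside the thiophene family, such as a phenyl ring or a carboxylic acid.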